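The source may report more compounds than this note shows. Statements on the series, on what has been measured and on what is new or still open speak of the compounds shown alone.

Of the compounds shown here, three of one family have been measured, and a fourth awaits measurement. Compound 1 `CN(C(=O)NC(=O)c1ccc(Cl)cc1Cl)c1nc(C(F)(F)F)c(C(=O)N/N=C/c2cccc(C(F)(F)F)c2)s1` was tested in a functional assay on MCF7 cells (Homo sapiens) for inhibition, read by MTT assay, with a stated time of 72 h (on this read-out higher numbers stand for weaker inhibition and lower numbers for stronger inhibition), where compound 1 gives 10.7 ug/mL. Compound 2 `CN(C(=O)NC(=O)c1ccc(Cl)cc1Cl)c1nc(C(F)(F)F)c(C(=O)N/N=C/c2ccc(C(F)(F)F)cc2)s1` shares the core of compound 1 and differs from it in one place: 4-(trifluoromethyl)phenyl in place of 3-(trifluoromethyl)phenyl on a carbon with a double bond to nitrogen. In this assay compound 2 gives 8.42 ug/mL, and the step of a 1.3-fold lower number from compound 1 to compound 2 (0.10 log units; within the scatter) shows how little that rearrangement moved the number. Compound 3 `CN(C(=O)NC(=O)c1ccccc1F)c1nc(C(F)(F)F)c(C(=O)N/N=C/c2cccc(C(F)(F)F)c2)s1` differs from compound 1 at another spot: 2-fluorophenyl in place of 2,4-dichlorophenyl on a carbonyl carbon. In this assay compound 3 gives 20.5 ug/mL, and the step of a 1.9-fold higher number from compound 1 to compound 3 (0.28 log units; within the scatter) again stays modest.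

Compound 4 `CN(C(=O)NC(=O)c1ccccc1F)c1nc(C(F)(F)F)c(C(=O)N/N=C/c2ccc(C(F)(F)F)cc2)s1` has not yet been measured. It stands to compound 3 exactly as compound 2 stands to compound 1, and the change is the same: 4-(trifluoromethyl)phenyl in place of 3-(trifluoromethyl)phenyl on a carbon with a double bond to nitrogen. Among the four compounds this change occurs twice, and the one time it has been measured it made the step of a 1.3-fold lower number from compound 1 to compound 2 (0.10 log units; within the scatter). The two pairs rest on cores that differ only in the way already described for compound 1 and compound 3.

For compound 4 the expected step is a 1.3-fold lower number from compound 3 to compound 4 (0.11 log units; within the scatter). Among the measured compounds shown here, this expectation rests on the single earlier instance, where the step of a 1.3-fold lower number from compound 1 to compound 2 (0.10 log units; within the scatter) was small. Compound 4 is therefore expected to give about 16 ug/mL in this assay, with a likely range from 8 ug/mL to 32 ug/mL.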

Compound 4, half-maximal inhibitory concentration: 4.98 ug/mL
Compound 4: the middle estimate sits 3.2-fold (0.51 log units) above what was measured; the whole stated range lies above it.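

In this assay, 4-(trifluoromethyl)phenyl in place of 3-(trifluoromethyl)phenyl on a carbon with a double bond to nitrogen gives a 4.1-fold lower number from compound 3 to compound 4 (0.61 log units; beyond the scatter), so this change does not carry over unaltered from one core to the other: the same change on two cores in this assay, a 1.3-fold lower number (0.10 log units; within the scatter) from compound 1 to compound 2 and a 4.1-fold lower number (0.61 log units; beyond the scatter) from compound 3 to compound 4, 3.2-fold (0.51 log units) apart, beyond the scatter of two such steps

The second change, 2-fluorophenyl in place of 2,4-dichlorophenyl on a carbonyl carbon, gives a 1.7-fold lower number from compound 2 to compound 4 (0.23 log units; within the scatter), and its two steps also disagree even though each one alone stays within the scatter: the same change on two cores in this assay, a 1.9-fold higher number (0.28 log units; within the scatter) from compound 1 to compound 3 and a 1.7-fold lower number (0.23 log units; within the scatter) from compound 2 to compound 4, 3.2-fold (0.51 log units) apart, beyond the scatter of two such steps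

These two comparisons are one finding seen from two sides, since they rest on the same four compounds: the two changes do not simply add up here, so a step measured on one core is a poor guide to the same step on the other, but nothing in these numbers shows why, or whether the same holds on any other core.

The compounds shown leave open whether a nitrile or a carboxylic acid in place of the trifluoromethyl group would also give steps that depend on the group on the carbonyl carbon. They also leave open how an unsubstituted phenyl on that carbonyl carbon would behave when paired with each of the two trifluoromethylphenyl groups.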